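Swapping the octyloxy chain for methylsulfanyl

This account rests on a few compounds, and the source may have more. Where it says the series, first, only, none or still open, it means among the compounds named here.

Compound 1: `CCCCCCCCOc1nc(N)nc2c1ncn2/C=C1/CC1(CO)CO` — > 20000 nM
Compound 2: `Nc1nc(NC2CCCC2)c2ncn(/C=C3/CC3(CO)CO)c2n1` — > 20000 nM

In an ADME assay on CCRF-HSB-2 cells (Homo sapiens) for cytotoxicity, with a stated time of 7 days (a higher number here means that more compound is tolerated, a lower number that less compound is tolerated), compound 1 gives > 20000 nM, which is a limit of the assay and not a number. Compound 2 gives > 20000 nM in this assay, likewise a limit. The step that the two limits leave unreadable from compound 1 to compound 2 therefore has no readable size, since both results rest on (the limit of > 20000 nM in this assay, at which 2 of the 2 values shown sit). Compound 1 thus stands only at a limit, with no numbered value beside it.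

Compound 3, `CSc1nc(N)nc2c1ncn2/C=C1/CC1(CO)CO`, remains to be measured. It differs from compound 1 by methylsulfanyl in place of octyloxy on an aromatic carbon. For the measured compounds named here, no measured step covers this change; the one step on record is itself unreadable. Nothing on record suggests the shared core becomes cytotoxic within the tested range. Compound 3 is therefore expected to give 30000 nM in this assay, with a range from 15000 nM to 100000 nM. The step that the limit leaves unreadable from compound 1 to compound 3 is expected to stay within the scatter.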

Compound 3, half-maximal cytotoxic concentration: > 100000 nM
Compound 3 gave a limit, no number; the forecaster's own chance of this, stated with the estimate: 80%; at least 3.3-fold (0.52 log units) between middle value and limit.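

In this assay compound 3 gives > 100000 nM, a limit and not a number, and compound 1 and compound 2 also rest on limits, so no step among compound 1, compound 2 and compound 3 can be read: the limit of > 100000 nM in this assay, at which 1 of the 3 values shown sits.

The compounds shown leave open at what concentration any of them turns cytotoxic, and whether the group on the aromatic carbon alters that.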